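The compounds below may be only part of what the source reports. "The series", "measured", "known", "first", "only" and "open" are said of these compounds alone.

Compound 1 `COc1ccc(C(=O)/C=C/c2ccc(OCc3cn(Cc4ccc(Br)cc4)nn3)cc2)cc1` carries a 4-bromobenzyl group and a methoxy group at opposite ends of the molecule. In a functional assay on MIA PaCa-2 cells (Homo sapiens) for inhibition, read by MTT assay, with a stated time of 48 h, tested at 10 uM (on this read-out higher numbers stand for more inhibition of growth at the one concentration tested and lower numbers for less inhibition of growth), compound 1 gives 56%. Compound 2 `COc1ccc(C(=O)/C=C/c2ccc(OCc3cn(Cc4ccccc4F)nn3)cc2)cc1` differs from it in one place, by 2-fluorophenyl in place of 4-bromophenyl on a saturated chain carbon bound to an aromatic nitrogen. In this assay compound 2 gives 19%, and so a number 37 percentage points lower from compound 1 to compound 2 (beyond the scatter). Compound 3 `O=C(/C=C/c1ccc(OCc2cn(Cc3ccc(Br)cc3)nn2)cc1)c1ccc([N+](=O)[O-])cc1` keeps the 4-bromobenzyl group of compound 1 but has a different core. In this assay compound 3 gives 17%, and so a number 39 percentage points lower from compound 1 to compound 3 (beyond the scatter). The values of compound 2 and compound 3 lie within the scatter of each other.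

Compound 4 `O=C(/C=C/c1ccc(OCc2cn(Cc3ccccc3F)nn2)cc1)c1ccc([N+](=O)[O-])cc1` has not yet been measured in this assay. It differs from compound 3 by 2-fluorophenyl in place of 4-bromophenyl on a saturated chain carbon bound to an aromatic nitrogen, which is the same change as that from compound 1 to compound 2, here made on the core of compound 3 instead; the two cores differ by nitro in place of methoxy on an aromatic carbon. The earlier step was large, but the starting point is now very different. A step of a number 5 percentage points lower from compound 3 to compound 4 (within the scatter) is expected, much smaller than the earlier one, since compound 3 already gives 17% and the read-out cannot fall far below that. For compound 4 the estimate in this assay is 12%, with a range from 0% to 30%.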

Compound 4, percent growth inhibition at one concentration: 22%
Compound 4: middle estimate off by 10 percentage points, on the low side, and the stated range covers the measured number.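

In this assay, placing 2-fluorophenyl for 4-bromophenyl on the core of compound 3 gives a number 5 percentage points higher from compound 3 to compound 4 (within the scatter), so the large fall seen on the core of compound 1 does not carry over to this second core: the same change on two cores in this assay, a number 37 percentage points lower (beyond the scatter) from compound 1 to compound 2 and a number 5 percentage points higher (within the scatter) from compound 3 to compound 4, 42 percentage points apart, beyond the scatter of two such steps. Read the other way, nitro in place of methoxy gives a number 3 percentage points higher from compound 2 to compound 4 (within the scatter), so that change also depends on its partner, with a large fall when the 4-bromobenzyl group is present and none that can be told from scatter when the 2-fluorobenzyl group is present: the same change on two cores in this assay, a number 39 percentage points lower (beyond the scatter) from compound 1 to compound 3 and a number 3 percentage points higher (within the scatter) from compound 2 to compound 4, 42 percentage points apart, beyond the scatter of two such steps. The two changes therefore do not add up in this set, since either one alone already brings the read-out into the range where compound 2, compound 3 and compound 4 cannot be told apart, but four compounds at one concentration show neither why this happens nor whether it holds on any other core.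

As far as these compounds go, it remains open which feature of the 4-bromobenzyl group matters, since a 4-fluorobenzyl or 4-chlorobenzyl group would separate the halogen from its place on the ring. From the compounds shown here alone, it also remains open whether a dimethylamino group or a hydroxyl group in place of the methoxy would keep the read-out of compound 1.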